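This account rests on a few compounds, and the source may have more. Where it says the series, first, only, none or still open, it means among the compounds named here.

Three compounds have been measured in a functional assay on PC-3 cells (Homo sapiens) for cytotoxicity, read by sulforhodamine B assay, tested at 10 uM; on this read-out lower numbers stand for less inhibition and higher numbers for more inhibition at the one concentration tested (going by the name of the read-out):

Compound 1, `CCCCc1ccc(-c2cc(-c3cn([C@H]4C[C@H](OC(C)=O)[C@@H](COC(C)=O)O4)c(=O)[nH]c3=O)on2)cc1`, gives 30.4%.
Compound 2, `CCCCCc1cc(-c2cn([C@H]3C[C@H](OC(C)=O)[C@@H](COC(C)=O)O3)c(=O)[nH]c2=O)on1`, gives 93.9%.
Compound 3, `CC(=O)OC[C@H]1O[C@@H](n2cc(-c3cc(-c4ccc(C(C)(C)C)cc4)no3)c(=O)[nH]c2=O)C[C@@H]1OC(C)=O`, gives 27.5%.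

Compound 3 stands at the low end of these three numbers. Its nearest neighbour is compound 1, a number 2.9 percentage points lower from compound 1 to compound 3 (within the scatter); the gap to compound 2 is of another kind, a number 66.4 percentage points lower from compound 2 to compound 3 (beyond the scatter), and the even larger step a number 63.5 percentage points higher from compound 1 to compound 2 (beyond the scatter) shows the same contrast between the pentyl compound and the two compounds carrying a substituted phenyl.

Compound 4, `CC(=O)OC[C@H]1O[C@@H](n2cc(-c3cc(-c4ccc(C(C)C)cc4)no3)c(=O)[nH]c2=O)C[C@@H]1OC(C)=O`, is still to be measured in this assay. It differs from compound 3 in one place: hydrogen in place of methyl on a saturated chain carbon bound to an aromatic carbon and two saturated chain carbons. For the measured compounds named here, the step that bears on this is the one from compound 1 to compound 3, where butyl gave way to tert-butyl on the aromatic carbon and the read-out stayed within the scatter. The large steps involving compound 2 concern the exchange of the whole substituted phenyl for pentyl and say little about trimming a methyl from tert-butyl. Since that one comparable change, a number 2.9 percentage points lower from compound 1 to compound 3 (within the scatter), lay within the scatter, compound 4 is expected to show a number 2.5 percentage points higher from compound 3 to compound 4 (within the scatter), no step beyond the scatter. The estimate for compound 4 in this assay is therefore 30%, with a range from 15% to 50%.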

Compound 4, a percentage reported as inhibition, at one concentration (the size of the read-out at that concentration, not a potency): 50.3%
For compound 4 the middle estimate is 20.3 percentage points below the measured one, and the stated range ends below it.
By their numbers in this assay, from the lowest: compounds 3 and 1 (each within the scatter of the next); then compound 4; then compound 2.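

In this assay, the carbon that carries the tert-butyl methyl groups proved sensitive to the loss of a single methyl, with a number 22.8 percentage points higher from compound 3 to compound 4 (beyond the scatter), and isopropyl also parted from butyl, with a number 19.9 percentage points higher from compound 1 to compound 4 (beyond the scatter), whereas the earlier match between compound 1 and compound 3 had made the choice of alkyl group on the phenyl look unimportant. The 4-substituted phenyl compounds therefore no longer form one flat group, although the exchange of pentyl for 4-isopropylphenyl still costs much of the read-out, with a number 43.6 percentage points lower from compound 2 to compound 4 (beyond the scatter). Nothing at hand explains why the isopropyl compound stands apart from its butyl and tert-butyl counterparts.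

The compounds shown leave open whether ethyl, methyl or plain hydrogen at this place on the phenyl would carry the number further up or back down, so a single step cannot yet be read as a trend with the size of the group. They also leave open how a hydroxyl or an amine on that same saturated chain carbon would read in this assay.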